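A few compounds are considered here, and "the series" means these few. Any claim that something is new, unique, unknown or untested is made for them only; others in the source may bear on it.

Compound 1 `CO[C@H]1C(=O)N2C(C(=O)C(C)(C)C)=C(C)CS(=O)(=O)[C@H]12` gives 130 h in a physicochemical assay for pharmacokinetics, at 37 degrees C; a lower number here means that the compound disappears faster, a higher number that the compound lasts longer.
Compound 2 `CO[C@H]1C(=O)N2C(C(=O)C(C)(C)C)=C(C)C(Sc3nnnn3C)S(=O)(=O)[C@H]12` gives 14.8 h in this assay.
Compound 3 `CO[C@H]1C(=O)N2C(C(=O)c3ccccc3)=C(C)C(Sc3nnnn3C)S(=O)(=O)[C@H]12` gives 120 h in this assay.

Compound 3 stands second of the three, close to compound 1 and far above compound 2, which sits lowest. Compound 4 `CO[C@H]1C(=O)N2C(C(=O)c3ccccc3)=C(CSc3nnnn3C)C(Sc3nnnn3C)S(=O)(=O)[C@H]12` differs from compound 3 by (1-methyl-1H-tetrazol-5-yl)sulfanyl in place of hydrogen on a saturated chain carbon bound to a double-bonded ring carbon. The closest comparison is the earlier addition of the same (1-methyl-1H-tetrazol-5-yl)sulfanyl group on a saturated ring carbon, which gave an 8.8-fold lower number from compound 1 to compound 2 (0.94 log units; beyond the scatter). Here the group enters at a different place, on a chain carbon, so the match is only partial, but a shorter half-life is the expected direction. Compound 4 is therefore expected to show a 4.8-fold lower number from compound 3 to compound 4 (0.68 log units; beyond the scatter), landing at about 25 h, with a likely range from 8 h to 80 h.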

Compound 4, half-life: 850 h
Compound 4: the middle estimate sits 34-fold (1.53 log units) below what was measured; the whole stated range lies below it.
By their numbers in this assay, from the lowest: compound 2; then compounds 3 and 1 (each within the scatter of the next); then compound 4.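

On a saturated chain carbon bound to a double-bonded ring carbon, (1-methyl-1H-tetrazol-5-yl)sulfanyl gives a 7.1-fold higher number from compound 3 to compound 4 (0.85 log units; beyond the scatter) in this assay, so the compound lasts longer. On a saturated ring carbon, with tert-butyl rather than phenyl on the carbonyl carbon, the same group gave an 8.8-fold lower number from compound 1 to compound 2 (0.94 log units; beyond the scatter) instead, so the group alone does not fix the direction of the change. Nothing available explains these opposite directions. From the compounds shown here alone, whether the longer half-life needs the phenyl stays open, as only compound 4 carries the group at this place. So does the outcome with an amine or a carboxylic acid on this chain carbon.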